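The compounds below may be only part of what the source reports. "The series", "measured", "known", "first", "only" and "open" are said of these compounds alone.

Measured so far in a functional assay; a lower number here means a stronger inhibitor, a higher number a weaker inhibitor:
compound 1 `CC(C)=CCOc1ccc2c(c1)OC(c1ccc(Cl)cc1)CC2=O` — compound 1 gives 6970 nM
compound 2 `CC(C)=CCOc1ccc2c(c1)OC(c1ccc(Br)cc1)CC2=O` — compound 2 gives 8120 nM
compound 3 `CC(C)=CCOc1ccc2c(c1)OC(c1ccc(C)cc1C)CC2=O` — compound 3 gives 8260 nM

Compound 2 holds the second highest of these three numbers, but all three sit within the scatter of one another: a 1.2-fold higher number from compound 1 to compound 2 (0.07 log units; within the scatter), a 1.0-fold higher number from compound 2 to compound 3 (0.01 log units; within the scatter) and a 1.2-fold higher number from compound 1 to compound 3 (0.07 log units; within the scatter). Each of these steps swaps the group on the saturated ring carbon and leaves the rest of the shared core untouched.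

Compound 4 `CC(C)=CCOc1cc(O)c2c(c1)OC(c1ccc(Br)cc1)CC2=O` keeps the 4-bromophenyl group of compound 2 and alters the core instead: hydroxy in place of hydrogen on an aromatic carbon. None of the three measured steps touches this part of the structure, so none of them bears on the change, and the data give no hint of a direction. With the measured compounds so close together and nothing pointing either way, the expected outcome is a step no larger than the scatter: a 1.2-fold lower number from compound 2 to compound 4 (0.06 log units; within the scatter). Compound 4 is therefore estimated at 7000 nM, with a wide range from 2500 nM to 20000 nM to allow for an untested kind of change.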

Compound 4, half-maximal inhibitory concentration: 2770 nM
Beside the measured number, compound 4's estimate is 2.5-fold (0.40 log units) above it; measured number inside the range.
By their numbers in this assay, from the lowest: compound 4; then compounds 1, 2 and 3 (each within the scatter of the next).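

Swapping the group on the saturated ring carbon moved nothing beyond the scatter, but adding a single hydroxy to an aromatic carbon of the core, ortho to a fused ring, gives a 2.9-fold lower number from compound 2 to compound 4 (0.47 log units; beyond the scatter) in this assay. For the compounds shown here, this is the first sign that the result responds to a change at this position, which is the same in compound 1, compound 2 and compound 3, and the step is towards a stronger inhibitor, though modest in size. Nothing among the data shown explains why the number falls with this change.

On these data alone, it remains open whether the hydroxy itself matters or whether a methoxy or an amine at the same position would give a similar step. As far as these compounds go, it is also open whether the hydroxy would give a similar step alongside the 4-chlorophenyl group of compound 1.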